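This account rests on a few compounds, and the source may have more. Where it says the series, first, only, none or still open, it means among the compounds named here.

Compound 1 `NC(=O)c1c(NC(=O)c2ccccc2Cl)sc2c1CCN(Cc1ccccc1F)C2`: in a functional assay on HeLa cells (Homo sapiens) for antiproliferative activity, with a stated time of 24 h (a higher number here means a weaker inhibitor, a lower number a stronger inhibitor), compound 1 gives > 50000 nM, which is a limit of the assay.
Compound 2 `NC(=O)c1c(NC(=O)c2ccccc2Cl)sc2c1CCN(C(=S)Nc1cccc3ccccc13)C2`: compound 2 gives 30800 nM.
Compound 3 `NC(=O)c1c(NC(=O)c2ccccc2Cl)sc2c1CCN(C(=S)Nc1ccccc1Br)C2`: compound 3 gives 24600 nM.

Compound 3 has the lowest of the two numbers in this assay, but the gap to its nearest neighbour, a 1.3-fold lower number from compound 2 to compound 3 (0.10 log units; within the scatter), lies within the scatter. The other comparison, an at least 2.0-fold lower number from compound 1 to compound 3 (0.30 log units; that floor lies within the scatter), rests on a limit of > 50000 nM in this assay, at which 1 of the 3 values shown sits, and is only a floor.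

Compound 4 `NC(=O)c1c(NC(=O)c2ccccc2Cl)sc2c1CCN(C(=S)Nc1c(Cl)cccc1Cl)C2` differs from compound 3 in one place: 2,6-dichlorophenyl in place of 2-bromophenyl on an amide-type nitrogen. Among the measured compounds shown here, the only measured change at this amide-type nitrogen, a 1.3-fold lower number from compound 2 to compound 3 (0.10 log units; within the scatter), moved the number within the scatter, so no step beyond the scatter is expected here either. Compound 4 is estimated at 25000 nM, within 10000 nM to 60000 nM, an expected step of a 1.0-fold higher number from compound 3 to compound 4 (0.01 log units; within the scatter).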

Compound 4, half-maximal inhibitory concentration: 26500 nM
Compound 4: middle estimate off by 1.1-fold (0.03 log units), on the low side; the range from low to high includes it.
By their numbers in this assay, from the lowest: compounds 3, 4 and 2 (each within the scatter of the next). At a limit, above all of these: compound 1.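

a 1.1-fold higher number from compound 3 to compound 4 (0.03 log units; within the scatter) in this assay comes with 2,6-dichlorophenyl in place of 2-bromophenyl on the amide-type nitrogen, and a 1.2-fold lower number from compound 2 to compound 4 (0.07 log units; within the scatter) comes with 2,6-dichlorophenyl in place of naphthalen-1-yl. Three different aromatic groups at this nitrogen, one of them now carrying two chlorines, therefore stay within the scatter of one another. The remaining step, an at least 1.8-fold lower number from compound 1 to compound 4 (0.27 log units; that floor lies within the scatter), rests on a limit and cannot be read: the limit of > 50000 nM in this assay, at which 1 of the 4 values shown sits.

As far as these compounds go, it remains open whether a pyridine ring, a carboxylic acid or an amine on a short chain at this nitrogen would move the number beyond the scatter.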